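Pyridin-2-yl for 4-methylphenyl on the triazole arm of compound 2

This account rests on a few compounds, and the source may have more. Where it says the series, first, only, none or still open, it means among the compounds named here.

Of the compounds shown here, three have so far been tested in a functional assay on SW480 cells (Homo sapiens) for cytotoxicity, read by MTT assay, with a stated time of 4 days; a lower number here means a stronger inhibitor, a higher number a weaker inhibitor. Compound 1 `C=C1C[C@]23C[C@@]1(O)CC[C@@H]2c1cccc(C)c1[C@@H]3Cn1cc(-c2ccc(Br)cc2)nn1` gives > 20000 nM, which is a limit of the assay rather than a number (the limit of > 20000 nM in this assay, at which 1 of the 3 values shown sits). Compound 2 `C=C1C(=O)[C@]23C[C@@]1(O)CC[C@H]2c1ccc(O)c(C)c1[C@@H]3Cn1cc(-c2ccc(C)cc2)nn1` gives 330 nM, the lowest of the two numbers on hand. Compound 3 `C=C1C(=O)[C@]23C[C@@]1(O)CC[C@H]2c1ccc(OS(=O)(=O)c2ccc(C)cc2)c(C)c1[C@@H]3Cn1cc(-c2ccc(C)cc2)nn1` gives 1460 nM; the step of a 4.4-fold higher number from compound 2 to compound 3 (0.65 log units; beyond the scatter) comes from putting (4-methylphenyl)sulfonyl in place of hydrogen on an oxygen on an aromatic ring.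

Compound 4 `C=C1C(=O)[C@]23C[C@@]1(O)CC[C@H]2c1ccc(O)c(C)c1[C@@H]3Cn1cc(-c2ccccn2)nn1` differs from compound 2 in another place: pyridin-2-yl in place of 4-methylphenyl on an aromatic carbon. For the measured compounds named here, the only measured step concerns the oxygen on the aromatic ring and leaves the group on the five-membered aromatic ring with 3 nitrogen untouched, so it offers no direct guide to this change. With nothing to point either way, a step no larger than the scatter in this assay is expected, a 1.5-fold higher number from compound 2 to compound 4 (0.18 log units; within the scatter). Compound 4 is therefore estimated at 500 nM, between 150 nM and 1700 nM.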

Compound 4, half-maximal inhibitory concentration: 410 nM
The estimate for compound 4 lay 1.2-fold (0.09 log units) above the measured number, within the range that was stated.
By their numbers in this assay, from the lowest: compounds 2 and 4 (each within the scatter of the next); then compound 3. At a limit, above all of these: compound 1.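

Replacing 4-methylphenyl with pyridin-2-yl on the triazole arm gives a 1.2-fold higher number from compound 2 to compound 4 (0.09 log units; within the scatter) in this assay, the first step shown at this position. The aryl group on this arm can therefore carry a ring nitrogen and a hydrogen-bond acceptor, and lose the methyl group, with the number staying within the scatter. Nothing measured on these compounds bears on why this is so.

Going by these compounds, only these two aromatic groups can be compared directly at this position, so it remains open whether an amine or a carboxylic acid on the ring, or a saturated ring such as morpholine in place of it, would stay within the scatter. Also open, on these data alone, is how pyridin-2-yl behaves when the hydroxyl on the shared core carries (4-methylphenyl)sulfonyl.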